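Hydroxy for methoxy in a pyrazole urea series

The source may report more compounds than this note shows. Statements on the series, on what has been measured and on what is new or still open speak of the compounds shown alone.

The series shares a core carrying a pyridyl group, a substituted phenyl group and a phenyl urea. Compound 1 `O=C(Nc1cccc(-n2cc(-c3ccncc3)c(-c3ccc(Cl)c(O)c3)n2)c1)Nc1cccc(C(F)(F)F)c1` carries the 4-chloro-3-hydroxyphenyl group with a trifluoromethyl on the urea phenyl. Compound 2 `COc1cc(-c2nn(-c3cccc(NC(=O)Nc4ccc(Cl)c(Cl)c4)c3)cc2-c2ccncc2)ccc1Cl` carries the 4-chloro-3-methoxyphenyl group with two chlorines on the urea phenyl. In a functional assay on Hs-578T cells (Homo sapiens) for inhibition, read by sulforhodamine B assay, with a stated time of 48 h (on this read-out lower numbers stand for stronger inhibition of growth and higher numbers for weaker inhibition of growth), compound 1 gives only a limit, > 32500 nM; this is the point described as the limit of > 32500 nM in this assay, at which 1 of the 2 values shown sits. In this assay compound 2 likewise gives only a limit, > 50000 nM, the point described as the limit of > 50000 nM in this assay, at which 1 of the 2 values shown sits. Compound 2 thus stands at the weaker end of what the assay can report, and no ordering between the two is possible.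

Compound 3 `O=C(Nc1cccc(-n2cc(-c3ccncc3)c(-c3ccc(Cl)c(O)c3)n2)c1)Nc1ccc(Cl)c(Cl)c1` is compound 2 with hydrogen in place of methyl on an oxygen on an aromatic ring, giving hydrogen in place of methyl on an oxygen on an aromatic ring; it combines the hydroxy group of compound 1 with the dichlorophenyl urea of compound 2. For the measured compounds named here, no measured step between two compounds is available for this change. Since both neighbours sit at a limit, compound 3 is expected to do the same, with the step from compound 2 to compound 3 estimated as a number no higher from compound 2 to compound 3 (the limit leaves the size open). The estimate for compound 3 in this assay is 50000 nM, within 20000 nM to 120000 nM.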

Compound 3, concentration for total growth inhibition: 3150 nM
Compound 3: middle estimate off by 16-fold (1.20 log units), on the high side; measured number outside the range, below it.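

In this assay, methoxy to hydroxy on the 4-chloro-3-methoxyphenyl group, with the 3,4-dichlorophenyl urea held constant, turns a limit into a measured number, the step being an at least 15-fold lower number from compound 2 to compound 3 (1.20 log units; beyond the scatter). With the 4-chloro-3-hydroxyphenyl group held constant, 3,4-dichlorophenyl in place of 3-(trifluoromethyl)phenyl on an amide-type nitrogen gives an at least 10-fold lower number from compound 1 to compound 3 (1.01 log units; beyond the scatter), so among these three compounds a measured number appears only where the hydroxy group and the 3,4-dichlorophenyl urea occur together, in compound 3. Both steps are minimum sizes, and nothing measured here accounts for either of them.

Going by these compounds, the hydroxy-for-methoxy change can be read only with the 3,4-dichlorophenyl urea, so its size with the 3-(trifluoromethyl)phenyl urea remains open. Also open, on these data alone, is how an amine or a carboxylic acid in place of the hydroxy group, or an ethyl group in place of the methyl on that oxygen, would read in this assay.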